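The source may report more compounds than this note shows. Statements on the series, on what has been measured and on what is new or still open speak of the compounds shown alone.

Measured compounds:
compound 1, `C[C@H](NC(=O)c1cc(Cl)ccc1O)C(=O)Nc1ccc(C(F)(F)F)cc1`: in a functional assay on K562 cells (Homo sapiens) for cytotoxicity, with a stated time of 72 h (on this read-out higher numbers stand for weaker inhibition and lower numbers for stronger inhibition), compound 1 gives > 12500 nM, a limit of the assay.
compound 2, `Cc1ccc(NC(=O)[C@H](C)NC(=O)c2cc(Cl)ccc2O)cc1`: in this assay compound 2 gives > 10000 nM, likewise a limit of the assay.

For the measured compounds named here, compound 1 therefore stands only at a limit in this assay, and the one companion value is a limit as well (the limit of > 12500 nM in this assay, at which 1 of the 2 values shown sits, (the limit of > 10000 nM in this assay, at which 1 of the 2 values shown sits)). Going by the values given here, the single measured step, a step that the two limits leave unreadable from compound 1 to compound 2, concerns the aromatic substituent and is left unreadable by the two limits. The move to compound 3, `CC(C)[C@H](NC(=O)c1cc(Cl)ccc1O)C(=O)Nc1ccc(C(F)(F)F)cc1`, is of another kind: isopropyl in place of methyl on a saturated chain carbon bound to an amide-type nitrogen and a carbonyl carbon. Among the compounds with values here, no measured step touches that place, and the one step that exists cannot be sized at all. Nothing in the data allows a shift beyond the scatter to be argued in either direction, so the expectation for compound 3 rests on the limit of compound 1 rather than on any step. Compound 3 is expected at 15000 nM, with a range from 4000 nM to 60000 nM. The step from compound 1 that this estimate means is a step that the limit leaves unreadable from compound 1 to compound 3, expected to stay within the scatter.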

Compound 3, half-maximal inhibitory concentration: 4500 nM
Compound 3: middle estimate off by 3.3-fold (0.52 log units), on the high side; measured number inside the range.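

The position on the saturated chain carbon bound to an amide-type nitrogen and a carbonyl carbon now gives the first readable difference in this series: in this assay, isopropyl in place of methyl gives an at least 2.7-fold lower number from compound 1 to compound 3 (0.44 log units; beyond the scatter). Compound 1 gives > 12500 nM, a limit of the assay, so the step fixes only a smallest size and its full size stays unknown: the limit of > 12500 nM in this assay, at which 1 of the 3 values shown sits. The step on the aromatic substituent cannot be read, which leaves compound 3 as the only compound shown with a number rather than a limit, and this change at the chain carbon as the only one with a direction.

What the compounds shown leave open is whether this single step belongs to any trend at the chain carbon, since an ethyl, a tert-butyl or a benzyl group there would be needed to tell a graded series from an isolated result. It is also open whether isopropyl at this place lowers the number in the same way when methyl replaces trifluoromethyl on the aromatic carbon, and nothing shown gives a cause for the step.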